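Methyl on the chain: an unmeasured step from compound 2

The source may report more compounds than this note shows. Statements on the series, on what has been measured and on what is new or still open speak of the compounds shown alone.

Measured so far:
compound 1, `COc1cccc(N2CCN(C(=O)C(C)N3C(=O)CCC3=O)CC2)c1`, 0%
compound 2, `CC(C(=O)N1CCN(c2ccccc2)CC1)N1C(=O)CCC1=O`, 0%
compound 3, `CC(C(=O)N1CCN(c2cccc(C(F)(F)F)c2)CC1)N1C(=O)CCC1=O`, 0%

All three measured compounds were tested in a functional assay on the whole organism (strain Swiss) with Mus musculus as the target, in the maximal electroshock model, with a stated time of 2 h, at a dose of 100 mg/kg by the intraperitoneal route; on this read-out higher numbers stand for a stronger effect at the one dose given and lower numbers for a weaker effect. Compound 1 gives 0%, compound 2 gives 0% and compound 3 gives 0%. The steps among them, no change at the digits printed from compound 1 to compound 2 (within the scatter), no change at the digits printed from compound 1 to compound 3 (within the scatter) and no change at the digits printed from compound 2 to compound 3 (within the scatter), all fall within the scatter, so compound 2 stands level with compounds 1 and 3.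

Compound 4, `CCC(C(=O)N1CCN(c2ccccc2)CC1)N1C(=O)CCC1=O`, has not yet been measured in this assay. It differs from compound 2 by methyl in place of hydrogen on a saturated chain carbon, two bonds along the chain from an amide-type nitrogen in a ring and a carbonyl carbon. Among the measured compounds shown here, none of the measured steps touches this chain carbon; all three vary only a group on the aromatic ring, and each left the read-out unchanged. For the measured compounds named here, the data therefore give no step of the same kind to lean on, only the observation that every compound of this core so far sits at the bottom of the scale in this assay.

On that basis compound 4 is expected to show no step beyond the scatter, no change at the digits printed from compound 2 to compound 4 (within the scatter). The estimate for compound 4 in this assay is 0%, with a range from 0% to 20%.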

Compound 4, a percentage reported as activity, at one dose (the size of the read-out at that dose, not a potency): 0%
The estimate for compound 4 equals the measured number at the digits printed, and the stated range covers the measured number.
By their numbers in this assay, from the lowest: compounds 1, 2, 3 and 4 (each within the scatter of the next).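

In this assay, the first change away from the aromatic ring, methyl in place of hydrogen on the saturated chain carbon, gives no change at the digits printed from compound 2 to compound 4 (within the scatter) and so extends the flat picture from the aromatic ring to this chain position. Compound 2 already gives 0%, so the step shows only that this methyl does not lift the read-out off the bottom of the scale at the one dose given, and it cannot tell whether the position would tolerate the change in a compound with activity to lose. No evidence on the reason for this result is available.

On these data alone, whether a longer chain such as propyl, a benzyl group, an amine or a carboxylic acid on this chain carbon would move the read-out in this assay remains open. Also open, as far as these compounds go, is whether methyl here would make any difference on a compound of this kind that gives a read-out clear of the scatter, since all the compounds shown sit together at the bottom of the scale.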